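From methoxy to trifluoromethyl on a shared core

The source may hold more compounds than are shown below. What is called first, only, known or untested is meant among the compounds shown, and "the series" means these compounds.

Among the compounds with values here, in a functional assay on the whole organism for antagonist activity, with Mus musculus as the target (a lower number here means that less compound is needed, a higher number that more compound is needed for the effect), compound 1 `CCC(=O)N(c1cccc(OC)c1)C1CCCC1N(C)C` gives 4 mg/kg, the lower of the two numbers measured so far, and compound 2 `CCC(=O)N(c1ccc(OC)c(OC)c1)C1CCCC1N(C)C` gives 10 mg/kg. Compound 3 `CCC(=O)N(c1cccc(C(F)(F)F)c1)C1CCCC1N(C)C` carries trifluoromethyl in place of methoxy on an aromatic carbon. Within the data shown here, only one measured step offers guidance, and only indirectly, since it leaves the exchanged methoxy untouched: adding another methoxy in place of hydrogen gave a 2.5-fold higher number from compound 1 to compound 2 (0.40 log units; beyond the scatter). A similarly modest move toward a higher number is therefore expected in this assay, an estimated 1.5-fold higher number from compound 1 to compound 3 (0.18 log units; within the scatter). For compound 3 the estimated value is 6 mg/kg, with an expected range of 2 mg/kg to 18 mg/kg.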

Compound 3, dose for half-maximal effect: 0.2 mg/kg
Estimate against measurement, compound 3: 30-fold (1.48 log units) above; measured number below the stated range.
By their numbers in this assay, from the lowest: compound 3; then compound 1; then compound 2.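

In this assay, the exchange of methoxy for trifluoromethyl on an aromatic carbon, meta to a large group, gave a 20-fold lower number from compound 1 to compound 3 (1.30 log units; beyond the scatter) as its outcome. The earlier step had shown only a modest rise on adding a methoxy, whereas this one shows that the group at this place can move the number far further, and in the opposite direction. Nothing available explains the size of this step.

Going by these compounds, it remains open whether a nitrile or a chlorine atom at this place would also give so low a number. Also open, on these data alone, is whether the added methoxy of compound 2 would raise the number on the trifluoromethyl compound as well.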